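Swapping a Methyl for a Methoxy Group

This account rests on a few compounds, and the source may have more. Where it says the series, first, only, none or still open, it means among the compounds named here.

Compound 1 `Cc1ccccc1C(=O)OC(CCN(C)C)c1ccc(Cl)cc1`: 1700 nM
Compound 2 `Cc1cccc(C(=O)OC(CCN(C)C)c2ccc(Cl)cc2)c1C`: 1150 nM

Both compounds were tested in an assay on NIH3T3 cells with Urotensin-2 receptor (Homo sapiens) as the target; on this read-out higher numbers stand for an effect only at larger amounts of compound and lower numbers for an effect already at smaller amounts. Compound 2 gives the lower of the two numbers, yet the step of a 1.5-fold lower number from compound 1 to compound 2 (0.17 log units; within the scatter) is within the scatter, so the two compounds cannot really be told apart on this read-out.

Compound 3 `COc1cccc(C(=O)OC(CCN(C)C)c2ccc(Cl)cc2)c1C` differs from compound 2 by methoxy in place of methyl on an aromatic carbon. For the measured compounds named here, the only measured step, from compound 1 to compound 2, concerns a methyl added to the ring and says nothing directly about exchanging a methyl for a methoxy group. Going by the values given here, with no step of that kind to draw on, and the one known step being within the scatter, a change in this assay beyond the scatter is not expected for compound 3. The expected value for compound 3 is therefore 1150 nM, with a range from 450 nM to 3000 nM; this estimate corresponds to the step of no change at the digits printed from compound 2 to compound 3 (within the scatter).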

Compound 3, half-maximal effective concentration: 1950 nM
Estimate against measurement, compound 3: 1.7-fold (0.23 log units) below; low and high end bracket the measured number.
By their numbers in this assay, from the lowest: compounds 2, 1 and 3 (each within the scatter of the next).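

Hydrogen, methyl and methoxy have now all been tried at this position, ortho to a methyl group and meta to a large group, and this assay does not tell them apart. Methoxy in place of methyl gives a 1.7-fold higher number from compound 2 to compound 3 (0.23 log units; within the scatter), while methoxy in place of hydrogen gives a 1.1-fold higher number from compound 1 to compound 3 (0.06 log units; within the scatter), so the extra oxygen and its hydrogen-bond acceptor leave no readable mark on this read-out. No separate measurement bears on this result.

Going by these compounds, whether an amine, a carboxylic acid or a longer chain such as butoxy at this position would move the number beyond the scatter remains open. Also open, on these data alone, is whether methoxy would give the same picture on a ring without the neighbouring methyl group.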